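The source may hold more compounds than are shown below. What is called first, only, known or untested is meant among the compounds shown, and "the series" means these compounds.

Measured compounds:
compound 1, `O=C1C(NC2CCCC2)=CC(=O)c2c1nc1n2[C@H]2OC[C@@H](O)[C@H]2OC1` — > 16000 nM
compound 2, `CCOc1ccccc1NC1=CC(=O)c2nc3n(c2C1=O)[C@H]1OC[C@@H](O)[C@H]1OC3` — 4630 nM

Compound 1, `O=C1C(NC2CCCC2)=CC(=O)c2c1nc1n2[C@H]2OC[C@@H](O)[C@H]2OC1`, carries a cyclopentyl group on the amine nitrogen. In a functional assay on ECa-109 cells for inhibition, with ECa-109 cell line (Homo sapiens) as the target, read by sulforhodamine B assay (a lower number here means a stronger inhibitor, a higher number a weaker inhibitor), compound 1 gives > 16000 nM, which is a limit of the assay rather than a number; it sits at the limit of > 16000 nM in this assay, at which 1 of the 2 values shown sits. Compound 2, `CCOc1ccccc1NC1=CC(=O)c2nc3n(c2C1=O)[C@H]1OC[C@@H](O)[C@H]1OC3`, is the other measured member of the set, and in this assay compound 2 gives 4630 nM, a number within the measurable range. Compound 3, `O=C1C(Nc2cccc(F)c2)=CC(=O)c2c1nc1n2[C@H]2OC[C@@H](O)[C@H]2OC1`, has not yet been measured. It differs from compound 1 in one respect: 3-fluorophenyl in place of cyclopentyl on an amine nitrogen, so that the cyclopentylamino of compound 1 becomes (3-fluorophenyl)amino in compound 3. With only compound 2 as a guide, which gives 4630 nM, a move toward a measurable number is expected, a step of an at least 2.2-fold lower number from compound 1 to compound 3 (0.35 log units; beyond the scatter) in this assay. Compound 3 is thus estimated at 7000 nM, with a range from 2500 nM to 20000 nM.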

Compound 3, half-maximal inhibitory concentration: 2370 nM
For compound 3 the middle estimate is 3.0-fold (0.47 log units) above the measured one; the whole stated range lies above it.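

Compound 3 gives the set its first pair that differs in one place, so the effect of the group on the amine nitrogen can now be read directly: in this assay, 3-fluorophenyl in place of cyclopentyl gives an at least 6.7-fold lower number from compound 1 to compound 3 (0.82 log units; beyond the scatter). Compound 1 stands at > 16000 nM, which is a limit of the assay and not a number. The step is therefore only a minimum, and its full size cannot be read because compound 1 is held at that limit: the limit of > 16000 nM in this assay, at which 1 of the 3 values shown sits.

The change replaces a five-membered carbon ring with an aromatic one and adds fluorine at once, and the compounds shown do not separate these two parts. As far as these compounds go, it remains open how a plain phenyl, a 3-chlorophenyl or a cyclohexyl group on the same nitrogen would read in this assay.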